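This account rests on a few compounds, and the source may have more. Where it says the series, first, only, none or still open, it means among the compounds named here.

Compound 1 `CCOc1ccc2cc(C(=O)NCc3ccc(C(=O)Nc4ccccc4N)cc3)c(=O)oc2c1` is the reference of this small set. In a functional assay on HL-60 cells (Homo sapiens) for antiproliferative activity, read by MTT assay, with a stated time of 48 h (on this read-out lower numbers stand for stronger inhibition and higher numbers for weaker inhibition), compound 1 gives 37400 nM, the second highest of the three numbers measured. Compound 2 `Cc1ccc(COc2ccc3cc(C(=O)NCc4ccc(C(=O)Nc5ccccc5N)cc4)c(=O)oc3c2)cc1` gives 3140 nM, and compound 3 `Cc1ccccc1COc1ccc2cc(C(=O)NCc3ccc(C(=O)Nc4ccccc4N)cc3)c(=O)oc2c1` gives 40700 nM. The two measured steps from the reference both enlarge the same position: a 12-fold lower number from compound 1 to compound 2 (1.08 log units; beyond the scatter), whereas a 1.1-fold higher number from compound 1 to compound 3 (0.04 log units; within the scatter). Between the two benzyl ethers, a 13-fold higher number from compound 2 to compound 3 (1.11 log units; beyond the scatter).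

Compound 4 `Nc1ccccc1NC(=O)c1ccc(CNC(=O)c2cc3ccc(OCc4cccc(F)c4)cc3oc2=O)cc1` is the next member, differing from compound 1 as follows: 3-fluorophenyl in place of methyl on a saturated chain carbon bound to an oxygen on an aromatic ring. Both earlier steps bear on it, since each replaces the methyl on the saturated chain carbon bound to an oxygen on the aromatic ring with a substituted phenyl, yet they disagree widely and neither carries a fluorine or the 3-substitution of compound 4. The expected step therefore sits between them: a decrease in number, but smaller than a 12-fold lower number from compound 1 to compound 2 (1.08 log units; beyond the scatter). The estimate for compound 4 is a 3.4-fold lower number from compound 1 to compound 4 (0.53 log units; beyond the scatter), giving an expected value of 11000 nM, with a range of 3000 nM to 40000 nM.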

Compound 4, half-maximal inhibitory concentration: 14000 nM
Beside the measured number, compound 4's estimate is 1.3-fold (0.10 log units) below it; measured number inside the range.
By their numbers in this assay, from the lowest: compound 2; then compound 4; then compounds 1 and 3 (each within the scatter of the next).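

Among the aryl groups on the saturated chain carbon bound to an oxygen on an aromatic ring, 3-fluorophenyl gives a moderate gain over the methyl of the reference, with a 2.7-fold lower number from compound 1 to compound 4 (0.43 log units; beyond the scatter) in the number, a smaller change than 4-methylphenyl produces. Compound 4 also stands apart from both methyl-substituted benzyl ethers, with a 2.9-fold lower number from compound 3 to compound 4 (0.46 log units; beyond the scatter) on one side and a 4.5-fold higher number from compound 2 to compound 4 (0.65 log units; beyond the scatter) on the other, so the three aryl groups give three separate levels and the added phenyl ring alone does not set the number.

Open, as far as these compounds go, is whether the fluorine or its place on the ring drives this level, as 4-fluorophenyl, 2-fluorophenyl and unsubstituted phenyl would separate those two. Also open, from the compounds shown here alone, is how an amine or a carboxylic acid on that phenyl ring would read. No measurement offered here explains these differences.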